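The compounds below may be only part of what the source reports. "The series", "measured", "known", "first", "only" and "open" are said of these compounds alone.

Compound 1 `O=C(N/N=C/C1CCCCC1)c1ccc(O[C@@H]2O[C@H](CO)[C@@H](O)[C@H](O)[C@H]2O)cc1` gives 0.88% in a functional assay on MDA-MB-231 cells (Homo sapiens) for inhibition, read by MTT assay, with a stated time of 24 h, tested at 100 uM; a lower number here means less inhibition, a higher number more inhibition at the concentration tested (going by the name of the read-out). Compound 2 `N#Cc1cccc(/C=N/NC(=O)c2ccc(O[C@@H]3O[C@H](CO)[C@@H](O)[C@H](O)[C@H]3O)cc2)c1` gives 6.17% in this assay.

On these two numbers compound 2 has the higher value, but the step of a number 5.3 percentage points higher from compound 1 to compound 2 (within the scatter) lies within the scatter, so no order between the two can be claimed. Compound 3 `O=C(N/N=C/c1ccc(Cl)cc1)c1ccc(O[C@@H]2O[C@H](CO)[C@@H](O)[C@H](O)[C@H]2O)cc1` differs from compound 2 by 4-chlorophenyl in place of 3-cyanophenyl on a carbon with a double bond to nitrogen. Within the data shown here, the only measured step that bears on this, an exchange of the group on the same carbon, was a number 5.3 percentage points higher from compound 1 to compound 2 (within the scatter), small. Compound 3 is therefore expected to show a step of about a number 1.2 percentage points lower from compound 2 to compound 3 (within the scatter), not beyond the scatter. The estimate for compound 3 is 5%, within 0% to 15%.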

Compound 3, a percentage reported as inhibition, at one concentration (the size of the read-out at that concentration, not a potency): 2.26%
Compound 3: middle estimate off by 2.7 percentage points, on the high side; measured number inside the range.
By their numbers in this assay, from the lowest: compounds 1, 3 and 2 (each within the scatter of the next).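

In this assay, 4-chlorophenyl in place of 3-cyanophenyl on a carbon with a double bond to nitrogen gives a small step (a number 3.9 percentage points lower from compound 2 to compound 3 (within the scatter)), and 4-chlorophenyl in place of cyclohexyl gives another (a number 1.4 percentage points higher from compound 1 to compound 3 (within the scatter)). All three groups tried at this place now stand within the scatter of one another, so none of them can be ranked. Nothing at hand explains these numbers. Still open, on these data alone, is whether an amine, a carboxylic acid or a longer chain on this carbon would give a step beyond the scatter.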